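Thiosemicarbazones of a quinoline aldehyde: third aryl variant

This account rests on a few compounds, and the source may have more. Where it says the series, first, only, none or still open, it means among the compounds named here.

Compound 1: `COc1ccccc1NC(=S)N/N=C/c1ccc2ccccc2n1` — in a functional assay on HeLa cells (Homo sapiens) for antiproliferative activity, read by sulforhodamine B assay, with a stated time of 72 h (on this read-out higher numbers stand for weaker inhibition and lower numbers for stronger inhibition), compound 1 gives > 100000 nM, a limit of the assay.
Compound 2: `COc1ccc(C)cc1NC(=S)N/N=C/c1ccc2ccccc2n1` — in this assay compound 2 gives > 100000 nM, again a limit.
Compound 3: `Fc1ccccc1NC(=S)N/N=C/c1ccc2ccccc2n1` — in this assay compound 3 gives > 100000 nM, also a limit.

Compound 3 therefore stands at the same limit as the other two measured members of the series; no number is known for it, only that its half-maximal inhibitory concentration lies beyond the range tested. The two measured steps, a step that the two limits leave unreadable from compound 1 to compound 2 and a step that the two limits leave unreadable from compound 1 to compound 3, cannot be sized, since both ends of each sit at the limit. Going by the values given here, the only evidence is the limit of > 100000 nM in this assay, at which 3 of the 3 values shown sit, which covers every value so far.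

Compound 4 is `Cc1cccc(NC(=S)N/N=C/c2ccc3ccccc3n2)c1`. The change from compound 3 is 3-methylphenyl in place of 2-fluorophenyl on an amide-type nitrogen. Neither measured step speaks to this exchange in a readable way, as both start and end at the limit. With nothing in the series showing measurable activity, the expectation for compound 4 is a step that the limit leaves unreadable from compound 3 to compound 4, most likely no measurable change, and a value of 150000 nM, expected between 30000 nM and 600000 nM, with a high chance that this assay again returns only a limit.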

Compound 4, half-maximal inhibitory concentration: > 100000 nM
Compound 4 ended at the assay's limit; the forecaster's own chance of this, stated with the estimate: 85%; the middle value lies beyond the limit too.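

Compound 4 sits at the limit in this assay, as do compound 1, compound 2 and compound 3, so no step among these compounds can be read: the limit of > 100000 nM in this assay, at which 4 of the 4 values shown sit.

The compounds shown leave open how far each true value lies past that limit, and whether any group on the amide-type nitrogen of the shared core gives a measurable half-maximal inhibitory concentration.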